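Swapping a Methyl for a Phenyl on the Ether Chain

The source may report more compounds than this note shows. Statements on the series, on what has been measured and on what is new or still open speak of the compounds shown alone.

Measured compounds in a functional assay on DLD-1 cells (Homo sapiens) for cytotoxicity, read by MTT assay, with a stated time of 48 h; on this read-out higher numbers stand for weaker inhibition and lower numbers for stronger inhibition:
- compound 1, `CCOc1ccc2c(Cl)ccnc2c1`: 2750 nM
- compound 2, `CC(C)Oc1ccc2c(Cl)ccnc2c1`: 3240 nM
- compound 3, `CCOc1ccc2c(NCCN(C)C)ccnc2c1`: 6240 nM

Among these three, compound 1 gives the lowest number in this assay. Compound 2 sits so close that a 1.2-fold higher number from compound 1 to compound 2 (0.07 log units; within the scatter) cannot be told apart from repeat measurements. Compound 3 stands furthest off: a 2.3-fold higher number from compound 1 to compound 3 (0.36 log units; beyond the scatter).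

The unmeasured compound 4, `Clc1ccnc2cc(OCc3ccccc3)ccc12`, differs from compound 1 only on the ether chain: phenyl in place of methyl on a saturated chain carbon bound to an oxygen on an aromatic ring

Going by the values given here, only one measured step bears on this place, the one from compound 1 to compound 2, where a methyl was added to the same saturated chain carbon and a 1.2-fold higher number from compound 1 to compound 2 (0.07 log units; within the scatter) stayed within the scatter. The change to compound 4 is larger in size, so a somewhat wider outcome is possible, yet nothing measured points in either direction. Compound 4 is therefore expected to land near compound 1, with a 1.1-fold higher number from compound 1 to compound 4 (0.04 log units; within the scatter) as the estimated step. In this assay compound 4 is estimated at 3000 nM, within a range from 1400 nM to 6500 nM.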

Compound 4, half-maximal inhibitory concentration: 3270 nM
Beside the measured number, compound 4's estimate is 1.1-fold (0.04 log units) below it; the measured number falls inside the stated range.
By their numbers in this assay, from the lowest: compounds 1, 2, 4 and 3 (each within the scatter of the next, the first and the last beyond it).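

In this assay, the ether chain takes a much larger change than the added methyl of compound 2, yet the step stays small: a 1.2-fold higher number from compound 1 to compound 4 (0.08 log units; within the scatter). Phenyl brings 6 heavy atoms and a six-membered aromatic ring to the saturated chain carbon bound to the oxygen, and even so the number cannot be told apart from that of compound 1, so this place tolerates a ring as well as a small branch on this read-out. No evidence at hand explains this result.

Still open, going by these compounds, is whether a longer chain between the oxygen and the phenyl, or an amine or a carboxylic acid on that phenyl, would leave the number just as unchanged. The compounds shown also leave open how the phenyl would behave with (2-(dimethylamino)ethyl)amino in place of chloro on the shared core.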